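Fluoro to ethyl on the benzoyl ring of compound 3

This account rests on a few compounds, and the source may have more. Where it says the series, first, only, none or still open, it means among the compounds named here.

Measured compounds:
Compound 1, `CC(C)(C)N(NC(=O)c1cccc(F)c1)C(=O)c1ccccc1Cl`, 69.2 nM
Compound 2, `COc1cccc(C(=O)NN(C(=O)c2ccccc2Cl)C(C)(C)C)c1`, 52.5 nM
Compound 3, `CC(C)(C)N(NC(=O)c1ccc(F)cc1)C(=O)c1ccccc1Cl`, 389 nM

Three compounds share one core and differ only in the substituent on one benzoyl ring, all measured in an assay on cells for agonist activity at ecdysone receptor (Bombyx mori), read by a luciferase reporter, with a stated time of 24 h; on this read-out lower numbers stand for an effect already at smaller amounts and higher numbers for an effect only at larger amounts of compound. Compound 3 stands at the highest number of the three: the step of a 5.6-fold higher number from compound 1 to compound 3 (0.75 log units; beyond the scatter) and the step of a 7.4-fold higher number from compound 2 to compound 3 (0.87 log units; beyond the scatter) both lie beyond the scatter, while the step of a 1.3-fold lower number from compound 1 to compound 2 (0.12 log units; within the scatter) does not.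

Compound 4, `CCc1ccc(C(=O)NN(C(=O)c2ccccc2Cl)C(C)(C)C)cc1`, has not yet been measured. It differs from compound 3 by ethyl in place of fluoro on an aromatic carbon.

For the measured compounds named here, none of the measured steps replaces a fluoro in this position with another group, so no step bears directly on the change. Going by the values given here, the only exchange of one group for another at a fixed position, a 1.3-fold lower number from compound 1 to compound 2 (0.12 log units; within the scatter), was within the scatter, and the two steps beyond the scatter concern a change of position rather than of group. On that footing no step beyond the scatter is expected for compound 4 in this assay, and the step of a 1.6-fold lower number from compound 3 to compound 4 (0.19 log units; within the scatter) is an estimate with wide uncertainty. Compound 4 is expected to give about 250 nM, within a range of 80 nM to 900 nM.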

Compound 4, half-maximal effective concentration: 5.75 nM
For compound 4 the middle estimate is 43-fold (1.64 log units) above the measured one; measured number outside the range, below it.
By their numbers in this assay, from the lowest: compound 4; then compounds 2 and 1 (each within the scatter of the next); then compound 3.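

In this assay, for the compounds shown here, a 68-fold lower number from compound 3 to compound 4 (1.83 log units; beyond the scatter) is the first step in this set to show that the group held at this one place, para to a large group, can move the number by itself, since the earlier large steps all involved a change of position as well as, or instead of, a change of group. Those steps left compound 3 with the highest number, which could be read as a penalty for the position itself, but the 4-ethylphenyl compound runs the other way, with a 12-fold lower number from compound 1 to compound 4 (1.08 log units; beyond the scatter) and a 9.1-fold lower number from compound 2 to compound 4 (0.96 log units; beyond the scatter). Among these four compounds, then, the position carries no fixed disadvantage: what it gives depends on the group placed there, and compound 4 has the lowest number of the four.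

Nothing in the data shown accounts for the gap between fluoro and ethyl at this place. Going by these compounds, it also stays open how the number would respond to a methyl, a longer chain such as propyl, or a tert-butyl at this position, and whether ethyl would give a similar number at the place held by the groups of compound 1 and compound 2.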